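Swapping the Fused Bicyclic Amine for a Methylpiperidine

This account rests on a few compounds, and the source may have more. Where it says the series, first, only, none or still open, it means among the compounds named here.

For the measured compounds named here, compound 2 `Nc1ccccc1NC(=O)c1ccc(CSC(=S)N2CCCc3ccccc32)cc1` gives 81.5% in a functional assay on A-375 cells (Homo sapiens) for antiproliferative activity, read by CCK-8 assay, with a stated time of 72 h, tested at 8 uM (on this read-out lower numbers stand for a weaker effect and higher numbers for a stronger effect at the one concentration tested), the lower of the two values measured so far; compound 1 `CN(C(=S)SCc1ccc(C(=O)Nc2ccccc2N)cc1)c1cccnc1` gives 87.7%, and that gap lies within the usual scatter. Compound 3 `CC1CCCCN1C(=S)SCc1ccc(C(=O)Nc2ccccc2N)cc1` differs from compound 2 by 2-methylpiperidin-1-yl in place of 1,2,3,4-tetrahydroquinolin-1-yl on a thiocarbonyl carbon. Going by the values given here, the only measured step, a number 6.2 percentage points lower from compound 1 to compound 2 (within the scatter), also exchanged one amine for another on the thiocarbonyl carbon and stayed within scatter, so a change of similar modest size is anticipated here. Compound 3 is therefore expected to give about 78%, in the range 62% to 90%. That estimate means a step of a number 3.5 percentage points lower from compound 2 to compound 3 (within the scatter), which is expected to remain within scatter.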

Compound 3, a percentage reported as inhibition, at one concentration (the size of the read-out at that concentration, not a potency): 85.2%
For compound 3 the middle estimate is 7.2 percentage points below the measured one; the measured number falls inside the stated range.
By their numbers in this assay, from the lowest: compounds 2, 3 and 1 (each within the scatter of the next).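

Replacing either earlier amine with 2-methylpiperidin-1-yl, which has no aromatic ring, gives in this assay a number 3.7 percentage points higher from compound 2 to compound 3 (within the scatter) and a number 2.5 percentage points lower from compound 1 to compound 3 (within the scatter), so an aromatic ring in the group on the thiocarbonyl carbon is not required for this read-out at the one concentration tested. All three amines shown at this place now lie within the scatter of one another. No measurement at hand offers an explanation for this.

From the compounds shown here alone, whether a morpholine ring or an open-chain diethylamino group would also stay within that scatter remains open. Lower concentrations might also separate these compounds.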